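The compounds below may be only part of what the source reports. "The series", "measured", "known", "first", "only" and "open" are said of these compounds alone.

Compound 3, `CCCc1c(OCCOCCOc2c(C(C)=O)ccc(OCC(=O)O)c2CCC)ccc(C(C)=O)c1O`, is one of three compounds for which inhibition of the cysteinyl leukotriene receptor has been recorded. In a functional assay on ileum (Cavia porcellus) for inhibition of cysteinyl leukotriene receptor (Homo sapiens) (a higher number here means a weaker inhibitor, a lower number a stronger inhibitor), compound 3 gives 200 nM, the second highest of the three numbers. Its nearest neighbour is compound 2, `CCCc1c(OCCCCCOc2c(C(C)=O)ccc(OCC(=O)O)c2CCC)ccc(C(C)=O)c1O`, which in this assay gives 100 nM, a value within the scatter of that of compound 3. The furthest is compound 1, `CCCc1c(OCCCOc2c(C(C)=O)ccc(OCCCCCC(=O)O)c2CCC)ccc(C(C)=O)c1O`, which in this assay gives 1000 nM, a number beyond the scatter from compound 3.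

Compound 4, `CCCc1c(OCCOCCOc2c(C(C)=O)ccc(OCCCCCC(=O)O)c2CCC)ccc(C(C)=O)c1O`, has not been measured. It differs from compound 3 in one place: 4-carboxybutyl in place of carboxy on a saturated chain carbon bound to an oxygen on an aromatic ring. Going by the values given here, no measured pair differs in only that place, so the size of this step cannot be read off directly. Among the compounds with values here, what the numbers show is that compound 1, the one measured compound carrying the longer acid-bearing chain, gives 1000 nM in this assay, the highest of the three, whereas compound 2 with the shorter chain gives 100 nM and compound 3 gives 200 nM; compound 1 also differs from them elsewhere in the molecule, so the comparison is not clean. The step is therefore expected to run toward a higher number, a 3.0-fold higher number from compound 3 to compound 4 (0.48 log units; beyond the scatter) in this assay, though it may yet fall within the scatter. Compound 4 is accordingly estimated at 600 nM in this assay, with a range from 200 nM to 2000 nM.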

Compound 4, half-maximal inhibitory concentration: 200 nM
The estimate for compound 4 lay 3.0-fold (0.48 log units) above the measured number; the range from low to high includes it.
By their numbers in this assay, from the lowest: compounds 2, 3 and 4 (each within the scatter of the next); then compound 1.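

In this assay, 4-carboxybutyl in place of carboxy on a saturated chain carbon bound to an oxygen on an aromatic ring gives no change at the digits printed from compound 3 to compound 4 (within the scatter), so on this core the longer acid-bearing chain leaves the number within the scatter. This also sets the earlier high number in a new light: compound 4 carries the same acid-bearing chain as compound 1 and differs from it in one place only, the chain joining the two parts of the molecule, and compound 4 gives 200 nM where compound 1 gives 1000 nM. No measurement on hand bears on why the step is this small.

The compounds shown leave open whether intermediate chains on the same oxygen, such as 2-carboxyethyl or 3-carboxypropyl, or a chain longer than 5-carboxypentyl, would also stay within the scatter of compound 3. They also leave open whether the acid itself can give way to a primary amide or a tetrazole at the end of the chain, and whether the all-carbon joining chain of compound 2 behaves in the same way when paired with 5-carboxypentyl.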